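Taking the 3-sulfopropyl chain off compound 3

This account rests on a few compounds, and the source may have more. Where it says the series, first, only, none or still open, it means among the compounds named here.

Measured in a functional assay for inhibition; on this read-out higher numbers stand for weaker inhibition and lower numbers for stronger inhibition:
Compound 1 `CC(C)(C)c1cc(-c2cc(=O)c3ccc(OCC(=O)N4CCN(Cc5ccccc5)CC4)cc3o2)cc(C(C)(C)C)c1O`: 3000 nM
Compound 2 `CCOC(=O)COc1ccc2c(=O)cc(-c3cc(C(C)(C)C)c(O)c(C(C)(C)C)c3)oc2c1`: 3000 nM
Compound 3 `CC(C)(C)c1cc(-c2cc(=O)c3ccc(OCCCS(=O)(=O)O)cc3o2)cc(C(C)(C)C)c1O`: 500 nM

Compound 3 holds the lowest number of the three, while compound 1 and compound 2 share the same higher value. The next compound, compound 4 `CC(C)(C)c1cc(-c2cc(=O)c3ccc(O)cc3o2)cc(C(C)(C)C)c1O`, differs from compound 3 as follows: hydrogen in place of 3-sulfopropyl on an oxygen on an aromatic ring. This places hydrogen in place of 3-sulfopropyl on an oxygen on an aromatic ring, leaving a hydroxy group.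

Going by the values given here, one measured step bears on this directly: a 6.0-fold lower number from compound 2 to compound 3 (0.78 log units; beyond the scatter). That modest step also changes the chain on this oxygen. Compound 1 carries a third, different chain there and matches compound 2 in value. Among the compounds with values here, no measured compound has the bare hydroxy group, so removal of the chain itself remains untested.

With only the sulfo-bearing chain standing apart, the expected step is a 4.0-fold higher number from compound 3 to compound 4 (0.60 log units; beyond the scatter), towards a higher number and of similar modest size. For compound 4 the estimated value in this assay is 2000 nM, with an expected range of 500 nM to 8000 nM.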

Compound 4, half-maximal inhibitory concentration: 1000 nM
Compound 4: the middle estimate sits 2.0-fold (0.30 log units) above what was measured; low and high end bracket the measured number.
By their numbers in this assay, from the lowest: compounds 3 and 4 (each within the scatter of the next); then compounds 1 and 2 (each within the scatter of the next).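

With this assay as the read-out, the swap of 3-sulfopropoxy for hydroxy comes out as a 2.0-fold higher number from compound 3 to compound 4 (0.30 log units; within the scatter), so the sulfo-bearing chain cannot be told apart from a bare hydroxy group at this oxygen on an aromatic ring. The hydroxy group does separate from the ester-bearing chain, with a 3.0-fold lower number from compound 2 to compound 4 (0.48 log units; beyond the scatter), so (ethoxycarbonyl)methyl on this oxygen goes with a higher number, whereas 3-sulfopropyl shows no measurable difference from hydrogen. Nothing given here accounts for these differences. The compounds shown leave open whether a carboxylic acid in place of the ethyl ester on this chain would sit with compound 3 and compound 4 or with compound 2. They also leave open where a simple methyl ether on this oxygen would fall.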